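Oxan-4-yl for 4,4-difluorocyclohexyl on the amide carbonyl

The source may report more compounds than this note shows. Statements on the series, on what has been measured and on what is new or still open speak of the compounds shown alone.

Working notes on the series. Compound 1 `CCCCN1CCc2nc(C#Cc3ccccc3)sc2C1` carries a butyl on the ring amine nitrogen; in an assay on HEK293 cells for positive allosteric modulation of metabotropic glutamate receptor 5 (Homo sapiens), read by FLIPR, with a stated time of 1 h (a higher number here means that more compound is needed for the effect, a lower number that less compound is needed), compound 1 gives 110 nM. Compound 2 `CCC(=O)N1CCc2nc(C#Cc3ccccc3)sc2C1` has a propanoyl in the same place. For compound 2 this assay reports only a limit, > 10000 nM, not a number. Compound 3 `O=C(C1CCC(F)(F)CC1)N1CCc2nc(C#Cc3ccccc3)sc2C1` is the amide bearing 4,4-difluorocyclohexyl on the carbonyl carbon; in this assay compound 3 gives 70 nM. The step of an at least 90-fold higher number from compound 1 to compound 2 (1.95 log units; beyond the scatter) is large, and the step of an at least 140-fold lower number from compound 2 to compound 3 (2.15 log units; beyond the scatter) is large in the other direction. Compound 3 thus holds the lowest of the two numbers shown, though its gap to compound 1 lies within the scatter, so no order between the two is claimed. Compound 4 `O=C(C1CCOCC1)N1CCc2nc(C#Cc3ccccc3)sc2C1` is not yet measured; it differs from compound 3 by oxan-4-yl in place of 4,4-difluorocyclohexyl on a carbonyl carbon. Going by the values given here, the only measured step at the carbonyl carbon, from compound 2 to compound 3, exchanged a short chain for a six-membered ring and was large; compound 4 keeps a six-membered ring, so a much smaller step is expected. The number for compound 4 is estimated at 200 nM, between 60 nM and 700 nM, corresponding to an expected step of a 2.9-fold higher number from compound 3 to compound 4 (0.46 log units; beyond the scatter).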

Compound 4, half-maximal effective concentration: 290 nM
The estimate for compound 4 lay 1.5-fold (0.16 log units) below the measured number; measured number inside the range.
By their numbers in this assay, from the lowest: compounds 3 and 1 (each within the scatter of the next); then compound 4. At a limit, above all of these: compound 2.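

In this assay, holding a six-membered ring on the carbonyl carbon does not make the ring's content neutral: oxan-4-yl for 4,4-difluorocyclohexyl gives a 4.1-fold higher number from compound 3 to compound 4 (0.62 log units; beyond the scatter) and this modest step is beyond the scatter. Compound 2 stands only at a limit of the assay, so the large step of an at least 34-fold lower number from compound 2 to compound 4 (1.53 log units; beyond the scatter) is a bound and not a measured size: the limit of > 10000 nM in this assay, at which 1 of the 4 values shown sits. Compound 3 lay within the scatter of the butyl amine compound 1, but the oxan-4-yl amide does not, with a 2.6-fold higher number from compound 1 to compound 4 (0.42 log units; beyond the scatter) as the modest step, so among the compounds shown the match between amide and amine holds for 4,4-difluorocyclohexyl and not for every six-membered ring on the carbonyl carbon.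

The compounds shown hold no plain cyclohexyl on the carbonyl carbon, so the step to oxan-4-yl cannot be divided between the loss of the two fluorines and the entry of the ring oxygen. As far as these compounds go, how a piperidin-4-yl, with an amine in the ring, or a smaller ring such as cyclobutyl would sit in this order remains open.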